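Carboxy for cyano on the thiophene carbon of compound 1

The source may hold more compounds than are shown below. What is called first, only, known or untested is meant among the compounds shown, and "the series" means these compounds.

Measured so far:
- compound 1 `CCN1CCc2c(sc(NC(=O)Nc3ccc(Cl)cc3)c2C#N)C1` gives > 25000 nM in a functional assay (strain AB) with Danio rerio as the target, read by microscopy, with a stated time of 1 h; on this read-out higher numbers stand for an effect only at larger amounts of compound and lower numbers for an effect already at smaller amounts
- compound 2 `CC(C)(C)OC(=O)CCC[N+]1(C)CCc2c(sc(NC(=O)Nc3ccc(Cl)cc3)c2C(N)=O)C1` gives 250 nM in this assay
- compound 3 `CCC1CCc2c(sc(NC(=O)Nc3ccc(Cl)cc3)c2C(N)=O)C1` gives > 25000 nM in this assay

The value of compound 1 in this assay is a limit of the assay and not a number. The same holds for compound 3, whose value is also a limit. Among the measured compounds shown here, only compound 2 gives a number in this assay, and it shares no single-point change with compound 1, so the two values show only that one compound has an effect where the other shows none up to the limit. Two of the three values shown sit at the limit (the limit of > 25000 nM in this assay, at which 2 of the 3 values shown sit), so compound 1 stands with the majority here.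

Compound 4 `CCN1CCc2c(sc(NC(=O)Nc3ccc(Cl)cc3)c2C(=O)O)C1` is not yet measured in this assay. It differs from compound 1 in one place: carboxy in place of cyano on an aromatic carbon. For the measured compounds named here, no step between two measured compounds matches this change, so there is no measured basis for expecting a shift in either direction beyond the scatter. The expected step from compound 1 to compound 4 is therefore a number no higher from compound 1 to compound 4 (the limit leaves the size open), with the chance that the assay again reports only a limit. Compound 4 is estimated at 25000 nM, within the range 5000 nM to 100000 nM.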

Compound 4, half-maximal effective concentration: > 25000 nM
Compound 4: no number, only a limit; the forecaster's own chance of this, stated with the estimate: 70%; the middle value sits exactly at the limit.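

In this assay compound 4 gives > 25000 nM as a limit of the assay and not a number. Among the compounds shown here, compound 1 also stands at a limit, so no step between compound 1 and compound 4 can be read: the limit of > 25000 nM in this assay, at which 3 of the 4 values shown sit. The compounds shown leave open whether carboxy in place of cyano on an aromatic carbon changes the effect in either direction.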